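The source may report more compounds than this note shows. Statements on the series, on what has been measured and on what is new or still open speak of the compounds shown alone.

Of the compounds shown here, two measured so far share one core. Compound 1 `CC[C@@H](Oc1ccccc1)C(=O)Nc1nc(-c2ccccc2)n[nH]1` carries a branched chain between the ether oxygen and the amide, while compound 2 `Cc1cccc(OCC(=O)Nc2nc(-c3ccccc3)n[nH]2)c1` carries a 3-methylphenyl on the ether oxygen. In an assay on CHO cells for displacement of a labelled ligand from adenosine receptor A3 (Homo sapiens), read by scintillation counting, with a stated time of 60 min (a higher number here means a weaker inhibitor, a lower number a stronger inhibitor), compound 1 gives 1900 nM. In this assay compound 2 gives 1500 nM. Of the two numbers, compound 2 shows the one that reads lowest, but compound 1 lies within the usual scatter of it, so the two cannot be told apart.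

Compound 3 `O=C(COc1ccccc1)Nc1nc(-c2ccccc2)n[nH]1` differs from compound 2 in one place: hydrogen in place of methyl on an aromatic carbon. Going by the values given here, no measured pair shows this particular step, so there is no direct guide to its size. Removing a single carbon from a ring edge is a small change, and the expectation is a step of a 1.5-fold higher number from compound 2 to compound 3 (0.17 log units; within the scatter), not beyond the scatter. Compound 3 is therefore estimated at 2200 nM, with a range from 900 nM to 5500 nM.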

Compound 3, inhibition constant: 2300 nM
Beside the measured number, compound 3's estimate is 1.0-fold (0.02 log units) below it; measured number inside the range.
By their numbers in this assay, from the lowest: compounds 2, 1 and 3 (each within the scatter of the next).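

In this assay the change from 3-methylphenyl to phenyl gives a 1.5-fold higher number from compound 2 to compound 3 (0.19 log units; within the scatter) at this ring position, so the methyl there, meta to a large group, makes no difference that can be told from the scatter. Compound 3 also shows the same for the saturated chain carbon, where hydrogen in place of ethyl gives a 1.2-fold higher number from compound 1 to compound 3 (0.08 log units; within the scatter) and the branch makes no readable difference either. Nothing measured here bears on these two results.

The compounds shown carry only hydrogen, methyl or ethyl at these places, so it remains open whether an amine, a carboxylic acid or a longer chain would move the number beyond the scatter. Going by these compounds, it is also open whether the methyl and the ethyl would read differently if both sat on one compound.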